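The compounds below may be only part of what the source reports. "The series", "measured", "known", "first", "only" and "open" are said of these compounds alone.

Measured compounds in a functional assay on MCF7 cells (Homo sapiens) for cytotoxicity, read by MTT assay, with a stated time of 48 h; a lower number here means a stronger inhibitor, a higher number a weaker inhibitor:

- compound 1 `O=C(Nc1nc2ccc(Cl)cc2s1)c1cc(-c2ccc(F)cc2)n2nc(-c3ccccc3)cc2n1`: 19800 nM
- compound 2 `COc1ccc(-c2cc(C(=O)Nc3nc4ccc(Cl)cc4s3)nc3cc(-c4ccccc4)nn23)cc1`: 4890 nM
- compound 3 `O=C(Nc1nc2ccc(F)cc2s1)c1cc(-c2ccc(F)cc2)n2nc(-c3ccccc3)cc2n1`: 22900 nM

Compound 1 and compound 3 carry the same aryl group on the shared part of the molecule and differ only in the core, where the counted difference is fluoro in place of chloro on an aromatic carbon. That change gives a 1.2-fold higher number from compound 1 to compound 3 (0.06 log units; within the scatter), so the two cores cannot be told apart in this assay on these two numbers.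

Compound 2 differs from compound 1 by methoxy in place of fluoro on an aromatic carbon. Going by the values given here, the change gives a 4.0-fold lower number from compound 1 to compound 2 (0.61 log units; beyond the scatter), the only step among the measured compounds that lies outside the scatter. It has been seen in one pair only, so nothing is yet known about whether it carries over to the other core.

Compound 4 `COc1ccc(-c2cc(C(=O)Nc3nc4ccc(F)cc4s3)nc3cc(-c4ccccc4)nn23)cc1` is not yet measured. It differs from compound 3 by methoxy in place of fluoro on an aromatic carbon. The place of the change reads the same as for the pair of compound 1 and compound 2, so this is the same change, applied on the core of compound 3 in place of the core of compound 1.

Because the cores differ by a 1.2-fold higher number from compound 1 to compound 3 (0.06 log units; within the scatter), the change is expected to behave much as it did before, and the expected step is a 4.0-fold lower number from compound 3 to compound 4 (0.60 log units; beyond the scatter), resting on a 4.0-fold lower number from compound 1 to compound 2 (0.61 log units; beyond the scatter). Compound 4 is therefore estimated at 5700 nM in this assay, with the measurement expected to fall between 2500 nM and 13000 nM.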

Compound 4, half-maximal inhibitory concentration: 35500 nM
Estimate against measurement, compound 4: 6.2-fold (0.79 log units) below; measured number above the stated range.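

In this assay the exchange of 4-fluorophenyl for 4-methoxyphenyl gives a 1.6-fold higher number from compound 3 to compound 4 (0.19 log units; within the scatter), so the drop in number seen on the core of compound 1 does not reappear on the core of compound 3: the same change on two cores in this assay, a 4.0-fold lower number (0.61 log units; beyond the scatter) from compound 1 to compound 2 and a 1.6-fold higher number (0.19 log units; within the scatter) from compound 3 to compound 4, 6.3-fold (0.80 log units) apart, beyond the scatter of two such steps

Read from the other side, fluoro in place of chloro on the core gives a 7.3-fold higher number from compound 2 to compound 4 (0.86 log units; beyond the scatter) among the 4-methoxyphenyl compounds, although it gave no readable step among the 4-fluorophenyl compounds, so the two changes cannot be treated as independent in this series: the same change on two cores in this assay, a 1.2-fold higher number (0.06 log units; within the scatter) from compound 1 to compound 3 and a 7.3-fold higher number (0.86 log units; beyond the scatter) from compound 2 to compound 4, 6.3-fold (0.80 log units) apart, beyond the scatter of two such steps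

These four compounds show that a step taken on one core was a poor guide to the other here, but they do not show why, nor whether the mismatch holds beyond this single set, and the whole gap rests on one pair on each core, with compound 2 the only one that stands apart from both of its neighbours.

Open, from the compounds shown here alone, is whether a second aryl replacement, such as one carrying an amine or a carboxylic acid in place of the fluoro, or a longer chain in place of the methoxy, would follow compound 2 or compound 4 on each core. Also open, going by these compounds, is how a core carrying a methyl or a plain hydrogen in place of the halogen would respond to the same exchange.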